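The source may hold more compounds than are shown below. What is called first, only, known or untested is meant among the compounds shown, and "the series" means these compounds.

Series notes. Compound 1 `Cc1c(O)ccc2c1[C@H](Cn1cc(-c3ccc(F)cc3)nn1)[C@@]13CC(=O)[C@@](C)(CC[C@@H]21)C3` and compound 2 `Cc1c(O)ccc2c1[C@H](Cn1cc(-c3ccccn3)nn1)[C@@]13CC(=O)[C@@](C)(CC[C@@H]21)C3` share one core; compound 3 `C=C1C[C@]23C[C@@]1(O)CC[C@H]2c1cc(Br)c(O)c(C)c1[C@@H]3Cn1cc(-c2ccc(F)cc2)nn1` and compound 4 `C=C1C[C@]23C[C@@]1(O)CC[C@H]2c1cc(Br)c(O)c(C)c1[C@@H]3Cn1cc(-c2ccccn2)nn1` share another, and the difference between the two cores is not broken down here. Cytotoxicity is read in a functional assay on A549 cells (Homo sapiens) for cytotoxicity, read by MTT assay, with a stated time of 4 days; a higher number here means a weaker inhibitor, a lower number a stronger inhibitor. In this assay compound 1 gives only a limit, > 20000 nM. Compound 2 likewise gives only a limit in this assay, > 20000 nM. The change from compound 1 to compound 2 is pyridin-2-yl in place of 4-fluorophenyl on an aromatic carbon, and the step it made is a step that the two limits leave unreadable from compound 1 to compound 2, since the limit of > 20000 nM in this assay, at which 2 of the 3 values shown sit, holds both values and leaves no number to compare. For the measured compounds named here, compound 3 is the one member of the set with a number in this assay, giving 17900 nM. The change from compound 3 to compound 4 is the same change, (pyridin-2-yl in place of 4-fluorophenyl on an aromatic carbon), made on the core of compound 3 instead of the core of compound 1. Its size on the core of compound 1 is not readable, so the expectation for compound 4 rests only on where compound 3 sits. The step from this change is expected to be a 1.2-fold higher number from compound 3 to compound 4 (0.09 log units; within the scatter), with a real chance that the assay again returns only a limit. The estimate for compound 4 is 22000 nM, expected to fall between 9000 nM and 45000 nM, because compound 3 in this assay gives 17900 nM.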

Compound 4, half-maximal inhibitory concentration: > 20000 nM
Compound 4: no number, only a limit; the forecaster's own chance of this, stated with the estimate: 60%; the middle value does not contradict the limit.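

In this assay, pyridin-2-yl in place of 4-fluorophenyl on the core of compound 3 gives an at least 1.1-fold higher number from compound 3 to compound 4 (0.04 log units; that floor lies within the scatter), so the data set only a floor on this step, and that floor does not show a real loss of activity. For the compounds shown here, the same change on the core of compound 1 cannot be read, which leaves one floor on one core and no size on the other, so the two cores offer no pair of steps to compare. Whether the change carries across cores with a similar size therefore stays unshown, and the data neither support nor exclude transfer, because almost the whole set sits at one limit: the limit of > 20000 nM in this assay, at which 3 of the 4 values shown sit.

Going by these compounds alone, compound 3 remains the only compound with a number, 17900 nM, so the true size of the step on its core, and whether any other group on the five-membered aromatic ring would give a readable value, stay open. A primary amine or a carboxylic acid in place of the 4-fluorophenyl, or a longer alkyl chain carrying either group, would be the kind of change that could test whether this position affects the read-out at all.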